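The compounds below may be only part of what the source reports. "The series", "measured", "known", "first", "only" and "open" are said of these compounds alone.

In a functional assay on ACHN cells (Homo sapiens) for inhibition, read by sulforhodamine B assay (on this read-out higher numbers stand for weaker inhibition of growth and lower numbers for stronger inhibition of growth), compound 1 (`CC(=O)Nc1ccc(CN2CCC=C(CCC(=O)NO)C2=O)cc1`) stands at "not determined" (no result reported), so the starting point of this account has no number. The only figure available comes from compound 2 (`O=C(CCC1=CCCN(CCCc2ccc(-c3ccccc3)cc2)C1=O)NO`), which carries a different substituent on the shared core and gives 2490 nM in this assay.

A single structural change leads onward from compound 1: phenyl in place of methyl on a carbonyl carbon. This is phenyl in place of methyl on a carbonyl carbon, or acetamido to benzamido, and it gives compound 3 (`O=C(CCC1=CCCN(Cc2ccc(NC(=O)c3ccccc3)cc2)C1=O)NO`). With no number for compound 1, the data cannot show how large this step is in this assay, and they favour neither direction. The working expectation is therefore a result with no gap beyond the scatter from the one available reference, compound 2 at 2490 nM. That reference is a single compound with a different substituent, so the range has to stay wide. For compound 3 the growth-inhibition concentration is estimated at 2000 nM, with an expected range of 600 nM to 6500 nM.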

Compound 3, concentration for 50% growth inhibition: > 10000 nM
Compound 3 was reported as a limit; the forecaster's own chance of this, stated with the estimate: 5%; at least 5.0-fold (0.69 log units) between middle value and limit.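

Among these compounds, compound 1 has no number in this assay, so no step to compound 3 can be read. Compound 3 gives > 10000 nM, which is a limit of the assay and not a number. The compounds shown leave open what the change from acetamido to benzamido does to growth inhibition in these cells.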